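Swapping an acid-bearing side chain for a fluorinated sulfur group

This account rests on a few compounds, and the source may have more. Where it says the series, first, only, none or still open, it means among the compounds named here.

Two compounds have been examined in a toxicity assay on MDCK cells (Canis lupus familiaris) for cytotoxicity, read by crystal violet staining, with a stated time of 48 h; on this read-out higher numbers stand for lower toxicity in this test and lower numbers for higher toxicity in this test. Compound 1, `Cc1ccc2cc(C(C)N(Cc3ccc(F)cc3)Cc3ccc(C(C)C)cc3)c(=O)[nH]c2c1`, gave a result that is a limit of the test rather than a number: in this assay compound 1 reads > 33000 nM. Compound 2, `Cc1ccc2[nH]c(=O)c(CN(Cc3ccc(OCC(=O)O)cc3)Cc3ccc(C(C)(C)C)cc3)cc2c1`, also reached only a limit; in this assay compound 2 reads > 10000 nM. So compound 2 stands at the limit of > 10000 nM in this assay, at which 1 of the 2 values shown sits, and the other value on record sits at the limit of > 33000 nM in this assay, at which 1 of the 2 values shown sits, so neither compound shows measurable toxicity within the tested range, and no step between measured compounds can be drawn.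

Compound 3, `Cc1ccc2[nH]c(=O)c(CN(Cc3ccc(SC(F)(F)F)cc3)Cc3ccc(C(C)(C)C)cc3)cc2c1`, has not yet been tested. It differs from compound 2 in one place: (trifluoromethyl)sulfanyl in place of carboxymethoxy on an aromatic carbon. The group that leaves carries a carboxylic acid; the group that enters carries three fluorine atoms on a carbon bound to sulfur. Among the measured compounds shown here, with both known values sitting at limits, there is no measured step to lean on, and the step expected from compound 2 to compound 3 in this assay is a step that the limit leaves unreadable from compound 2 to compound 3, a small shift toward higher toxicity that may well stay within the scatter. Compound 3 is therefore estimated at 20000 nM, with a range from 5000 nM to 60000 nM.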

Compound 3, half-maximal cytotoxic concentration: > 5000 nM
Compound 3 was reported as a limit; the forecaster's own chance of this, stated with the estimate: 60%; the middle value does not contradict the limit.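

Among the compounds shown here, compound 2 and compound 3 both gave only a limit in this assay, so the change from carboxymethoxy to (trifluoromethyl)sulfanyl yields no step that can be read. The compounds shown leave open at what concentration, if any, each of them would harm these cells, and whether this change shifts that concentration.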